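The source may report more compounds than this note shows. Statements on the series, on what has been measured and on what is new or still open speak of the compounds shown alone.

Measured compounds in an assay on isolated protein for activation of cGMP-dependent protein kinase 1 (Homo sapiens), read by ADP-Glo, with stated times of 120 min and 40 min; a lower number here means that less compound is needed, a higher number that more compound is needed for the effect:

compound 1, `OC[C@@H](O[C@H]1CCCN(Cc2cccc3nonc23)[C@H]1c1ccccc1)c1cc(Cl)cc(Cl)c1`: 8000 nM
compound 2, `OC[C@@H](O[C@H]1CCCN(Cc2ccc(-c3nn[nH]n3)cc2)[C@H]1c1ccccc1)c1cc(Cl)cc(Cl)c1`: 131000 nM
compound 3, `O=C(O)c1ccc(CN2CCC[C@H](O[C@H](CO)c3cc(Cl)cc(Cl)c3)[C@@H]2c2ccccc2)cc1`: 11000 nM

Compound 3 sits close to compound 1: the step of a 1.4-fold higher number from compound 1 to compound 3 (0.14 log units; within the scatter) is within the scatter, so the two cannot be ranked against each other. Against compound 2 the gap is clear, a 12-fold lower number from compound 2 to compound 3 (1.08 log units; beyond the scatter), and that step is the only large one in which compound 3 takes part.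

Compound 4, `O=C(O)c1cncc(CN2CCC[C@H](O[C@H](CO)c3cc(Cl)cc(Cl)c3)[C@@H]2c2ccccc2)c1`, differs from compound 3 by 5-carboxypyridin-3-yl in place of 4-carboxyphenyl on a saturated chain carbon bound to an amine nitrogen in a ring.

Going by the values given here, none of the measured steps bears directly on this change. The step of a 16-fold higher number from compound 1 to compound 2 (1.21 log units; beyond the scatter) and the step of a 12-fold lower number from compound 2 to compound 3 (1.08 log units; beyond the scatter) both alter the group attached to the six-membered aromatic ring of carbon only, not the ring itself, and in every measured compound that ring is carbon only. Among the compounds with values here, the carboxy is kept in compound 4, so the only guide is that no measured step shows what replacing that ring with one holding one hetero atom does. A step within the scatter is therefore expected, no change at the digits printed from compound 3 to compound 4 (within the scatter), with no direction claimed. Compound 4 is estimated at 11000 nM, within 4000 nM to 30000 nM.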

Compound 4, half-maximal effective concentration in the cGMP-dependent protein kinase 1 assay: 34000 nM
Compound 4: the middle estimate sits 3.1-fold (0.49 log units) below what was measured; measured number above the stated range.
By their numbers in the cGMP-dependent protein kinase 1 assay, from the lowest: compounds 1 and 3 (each within the scatter of the next); then compound 4; then compound 2.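

In the cGMP-dependent protein kinase 1 assay, this position responds to the ring itself and not only to the group on it: with the carboxy kept, 5-carboxypyridin-3-yl gives a 3.1-fold higher number from compound 3 to compound 4 (0.49 log units; beyond the scatter). Compound 4 also stands clear of the other two compounds, with a 3.9-fold lower number from compound 2 to compound 4 (0.59 log units; beyond the scatter) and a 4.3-fold higher number from compound 1 to compound 4 (0.63 log units; beyond the scatter). In a physicochemical assay for solubility, read by HPLC, with a stated time of 24 h, at pH 7 (on this read-out higher numbers stand for higher solubility and lower numbers for lower solubility), compound 3 gives 85000 nM and compound 4 gives 74000 nM, so a 1.1-fold lower number from compound 3 to compound 4 (0.06 log units; within the scatter) shows that this change leaves no readable difference on that read-out.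

No measurement shown offers an explanation for the step from 4-carboxyphenyl to 5-carboxypyridin-3-yl. The compounds shown leave open how much of that step belongs to the ring nitrogen and how much to the different placement of the carboxy, and what an amide would do in place of the carboxy of 5-carboxypyridin-3-yl.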